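The source may hold more compounds than are shown below. What is called first, only, known or untested is meant among the compounds shown, and "the series" means these compounds.

In a functional assay on HCT-116 cells (Homo sapiens) for inhibition, read by MTT assay, with a stated time of 72 h (a higher number here means a weaker inhibitor, a lower number a stronger inhibitor), compound 1 `COc1cc(Oc2cccc(Nc3ccccc3)c2)cc(OC)c1CNCc1ccccc1` gives 4070 nM. Compound 2 `CCN1CCN(Cc2c(OC)cc(Oc3cccc(Nc4ccccc4)c3)cc2OC)CC1` gives > 20000 nM, which is a limit of the assay and not a number. Compound 3 `COc1cc(Oc2cccc(Nc3ccccc3)c2)cc(OC)c1CNC(C)C` likewise gives > 20000 nM, a limit rather than a measured number, so its true standing is known only as beyond that mark. Both steps away from compound 1 went the same way: an at least 4.9-fold higher number from compound 1 to compound 2 (0.69 log units; beyond the scatter) and an at least 4.9-fold higher number from compound 1 to compound 3 (0.69 log units; beyond the scatter), while the step that the two limits leave unreadable from compound 2 to compound 3. Compound 4 `COc1cc(Oc2cccc(Nc3ccccc3)c2)cc(OC)c1CNCc1ccc(O)cc1` differs from compound 3 by 4-hydroxybenzyl in place of isopropyl on an amine nitrogen, restoring a benzyl-like group similar to compound 1. The step from isopropyl to this group is therefore expected to give a lower number: an at least 4.4-fold lower number from compound 3 to compound 4 (0.64 log units; beyond the scatter). Compound 4 is estimated at 4500 nM, with a range from 1500 nM to 16000 nM.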

Compound 4, half-maximal inhibitory concentration: 3360 nM
Compound 4: middle estimate off by 1.3-fold (0.13 log units), on the high side; low and high end bracket the measured number.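

On the amine nitrogen, a benzyl-type group again gives the lower number, now with 4-hydroxybenzyl: an at least 5.9-fold lower number from compound 3 to compound 4 (0.77 log units; beyond the scatter), and an at least 5.9-fold lower number from compound 2 to compound 4 (0.77 log units; beyond the scatter). Hydroxy in place of hydrogen on an aromatic carbon gives a 1.2-fold lower number from compound 1 to compound 4 (0.08 log units; within the scatter), so this hydroxy makes no readable difference. The first two steps are only minimum sizes because each starts from a limit of the assay: the limit of > 20000 nM in this assay, at which 2 of the 4 values shown sit.

As far as these compounds go, whether a methoxy or a fluorine in place of that hydroxy would give a different number stays open. So does the effect of a phenethyl group in place of benzyl.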